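Swapping Nitro for Chloro: Does Cell Tolerance Change?

The source may hold more compounds than are shown below. What is called first, only, known or untested is meant among the compounds shown, and "the series" means these compounds.

Measured so far:
compound 1 `O=C(COc1cccc2ccccc12)N/N=C/c1ccc(Cl)cc1`: 87.6 ug/mL
compound 2 `C/C(=N\NC(=O)COc1cccc2ccccc12)c1ccc([N+](=O)[O-])cc1`: 89.3 ug/mL
compound 3 `O=C(COc1cccc2ccccc12)N/N=C/c1ccc([N+](=O)[O-])cc1`: 87.9 ug/mL

All three compounds were tested in an ADME assay on MT4 cells (Homo sapiens) for cytotoxicity, read by MTT assay, with a stated time of 4 days; a lower number here means that less compound is tolerated, a higher number that more compound is tolerated. Compound 3 and compound 1 differ in one place, (chloro in place of nitro on an aromatic carbon), and this change gave a 1.0-fold lower number from compound 3 to compound 1 (0.00 log units; within the scatter), so the two values show the same tolerance. Compound 2 shares the naphthyloxy-acetohydrazide part with compound 3, but the difference between the two cores is not broken down here; their values in this assay lie within the usual scatter of each other, so nothing separates them.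

Compound 4 `C/C(=N\NC(=O)COc1cccc2ccccc12)c1ccc(Cl)cc1` is not yet measured. It relates to compound 2 as compound 1 relates to compound 3: chloro in place of nitro on an aromatic carbon, with the place described in the same words, so this is the same change. Because a 1.0-fold lower number from compound 3 to compound 1 (0.00 log units; within the scatter) showed no shift, the expected step is a 1.0-fold lower number from compound 2 to compound 4 (0.00 log units; within the scatter). Compound 4 is therefore estimated at 89 ug/mL, with a likely range from 60 ug/mL to 130 ug/mL.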

Compound 4, half-maximal cytotoxic concentration in the MT4 assay: 4.07 ug/mL
Compound 4: the middle estimate sits 22-fold (1.34 log units) above what was measured; measured number below the stated range.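

In the MT4 assay, chloro in place of nitro gave a 22-fold lower number from compound 2 to compound 4 (1.34 log units; beyond the scatter), so the result of this change on one core did not carry over to the other: the same change on two cores in the MT4 assay, a 1.0-fold lower number (0.00 log units; within the scatter) from compound 3 to compound 1 and a 22-fold lower number (1.34 log units; beyond the scatter) from compound 2 to compound 4, 22-fold (1.34 log units) apart, beyond the scatter of two such steps In a physicochemical assay for lipophilicity, measured as octanol-water partition (on this read-out lower numbers stand for lower lipophilicity and higher numbers for higher lipophilicity), compound 2 gives 3.37 and compound 4 gives 4.17, so the same change also raised the number on the core of compound 2: the measured partition coefficient of compound 2, 3.37, and of compound 4, 4.17, a number 0.80 log units higher (beyond the scatter) This shows that a flat result for this change on one core is no safe guide to another core, but it does not show why, since the partition coefficients shown cover only one core and so cannot be tied to the gap between the two steps, and two pairs set no rule for the whole series.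

From the compounds shown here alone, it remains open whether other groups in the place of the nitro, such as an amine, a methoxy group or a carboxylic acid, would behave as on the core of compound 1 or as on the core of compound 2. Also open is which part of the difference between the two cores matters, as only these two cores are shown.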